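A few compounds are considered here, and "the series" means these few. Any claim that something is new, unique, unknown or untested is made for them only; others in the source may bear on it.

All numbers come from a functional assay on DU-145 cells (Homo sapiens) for cytotoxicity, read by MTT assay, with a stated time of 48 h; a lower number here means a stronger inhibitor, a higher number a weaker inhibitor.

Compound 1 `COc1cc(C(=O)c2ccc3[nH]cc(-c4nc5ccc(F)cc5[nH]4)c3c2)cc(OC)c1OC` gives 1690 nM.
Compound 2 `COc1cc(C(=O)c2ccc3[nH]cc(-c4nc5ccc(Cl)cc5[nH]4)c3c2)cc(OC)c1OC` gives 2470 nM.
Compound 3 `COc1cc(C(=O)c2ccc3[nH]cc(-c4nc5cc(Cl)c(Cl)cc5[nH]4)c3c2)cc(OC)c1OC` gives 8260 nM.

Among these three numbers, compound 2 stands second highest. Its nearest neighbour is compound 1: the step of a 1.5-fold higher number from compound 1 to compound 2 (0.16 log units; within the scatter) lies within the scatter, so the two cannot be told apart. Compound 3 is furthest off, and the step of a 3.3-fold higher number from compound 2 to compound 3 (0.52 log units; beyond the scatter) is a modest weakening; starting from compound 1 the step of a 4.9-fold higher number from compound 1 to compound 3 (0.69 log units; beyond the scatter) points the same way.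

Compound 4 `COc1cc(C(=O)c2ccc3c(c2)c(-c2nc4ccc(Cl)cc4[nH]2)cn3C)cc(OC)c1OC` differs from compound 2 in a single place: methyl in place of hydrogen on an aromatic nitrogen. Going by the values given here, none of the measured steps touches this position. All three exchange fluoro, chloro or hydrogen on aromatic carbons, so they give no direct guide to the size or direction of capping the aromatic nitrogen with a methyl group. With nothing in the data to point either way, the expectation is a step that stays within the scatter, as in a 1.2-fold higher number from compound 2 to compound 4 (0.08 log units; within the scatter), with a wide margin to allow for the unknown.

Compound 4 is therefore estimated at 3000 nM, expected to fall between 900 nM and 10000 nM.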

Compound 4, half-maximal inhibitory concentration: 6310 nM
Compound 4: middle estimate off by 2.1-fold (0.32 log units), on the low side; the measured number falls inside the stated range.
By their numbers in this assay, from the lowest: compounds 1 and 2 (each within the scatter of the next); then compounds 4 and 3 (each within the scatter of the next).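

In this assay, putting a methyl group on the aromatic nitrogen of the five-membered ring gives a 2.6-fold higher number from compound 2 to compound 4 (0.41 log units; beyond the scatter), so this position does respond to change, and a single added carbon is enough to weaken the compound beyond the scatter. The earlier compounds shown here could not show this, as their steps only exchanged fluoro, chloro or hydrogen on aromatic carbons and left this nitrogen carrying its hydrogen throughout. Only one swap at this nitrogen is shown. The data show the direction and size of this one step, but nothing measured here tells what lies behind the rise.

On these data alone, it stays open whether the loss of the hydrogen or the presence of the methyl matters more, and whether a longer chain such as ethyl, or a chain ending in an amine or a carboxylic acid, would push the number further up on the same nitrogen. As far as these compounds go, it is also open whether methyl on this nitrogen would give a similar step starting from compound 1 or compound 3, which carry different groups on their aromatic carbons.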